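The source may hold more compounds than are shown below. What is called first, only, known or untested is meant among the compounds shown, and "the series" means these compounds.

Measured so far in a functional assay on a cell-free system (Platelet, plasma, Oryctolagus cuniculus) for inhibition, with a stated time of 5 min, at 37 degrees C; a higher number here means a weaker inhibitor, a lower number a stronger inhibitor:
- compound 1 `Cc1nc(C)c(C(=O)Oc2ccccc2/C=C/C(=O)O)nc1C`: 9600 nM
- compound 2 `COc1ccc(/C=C/C(=O)O)c(OC(=O)c2nc(C)c(C)nc2C)c1`: 134000 nM
- compound 3 `CCOC(=O)/C=C/c1ccc(OC)cc1OC(=O)c1nc(C)c(C)nc1C`: 28200 nM

Compound 3 holds the middle place of these numbers, higher than compound 1 and lower than compound 2. Compound 4 `CCOC(=O)/C=C/c1ccccc1OC(=O)c1nc(C)c(C)nc1C` has hydrogen in place of methoxy on an aromatic carbon of compound 3 (hydrogen in place of methoxy on an aromatic carbon). For the measured compounds named here, the closest precedent is the large step of a 14-fold higher number from compound 1 to compound 2 (1.14 log units; beyond the scatter), where methoxy replaced hydrogen, so the reverse change points to a lower number. Going by the values given here, the modest step of a 4.8-fold lower number from compound 2 to compound 3 (0.68 log units; beyond the scatter) shows that ethyl in place of hydrogen also moves the number, and no pair shows the methoxy change with ethyl present. A somewhat smaller, though still clear, fall is therefore expected in this assay. The expected step is a 7.1-fold lower number from compound 3 to compound 4 (0.85 log units; beyond the scatter). The estimate for compound 4 is 4000 nM, within an expected range of 1200 nM to 14000 nM.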

Compound 4, half-maximal inhibitory concentration: 110000 nM
Estimate against measurement, compound 4: 28-fold (1.44 log units) below; the measured number lies above the stated range.
By their numbers in this assay, from the lowest: compound 1; then compound 3; then compounds 4 and 2 (each within the scatter of the next).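

Taking methoxy off this aromatic carbon, para to the 2-(ethoxycarbonyl)ethenyl group, gives a 3.9-fold higher number from compound 3 to compound 4 (0.59 log units; beyond the scatter), so the direction of the methoxy change depends on the core: the same change on two cores in this assay, a 14-fold higher number (1.14 log units; beyond the scatter) from compound 1 to compound 2 and a 3.9-fold lower number (0.59 log units; beyond the scatter) from compound 4 to compound 3, 54-fold (1.74 log units) apart, beyond the scatter of two such steps. Ethyl on the oxygen next to a carbonyl group also reverses direction once methoxy is absent, giving an 11-fold higher number from compound 1 to compound 4 (1.06 log units; beyond the scatter): the same change on two cores in this assay, a 4.8-fold lower number (0.68 log units; beyond the scatter) from compound 2 to compound 3 and an 11-fold higher number (1.06 log units; beyond the scatter) from compound 1 to compound 4, 54-fold (1.74 log units) apart, beyond the scatter of two such steps. Neither change therefore carries a fixed direction across these four compounds.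

Open, going by these compounds, is whether a hydroxyl or a fluorine at this aromatic carbon behaves as methoxy does. Also open, on these data alone, is how a methyl or a propyl in place of the ethyl would read on either core.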